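The source may hold more compounds than are shown below. What is called first, only, known or untested is meant among the compounds shown, and "the series" means these compounds.

Compound 3 `CCN(Cc1ccco1)C(=O)COc1ccc(C)cc1` is the weaker of two analogues that replace the thiophene of compound 1 `CCN(Cc1cccs1)C(=O)COc1ccc(C)cc1` with another five-membered heteroaromatic ring. In an assay on HEK293 cells for agonist activity at transient receptor potential cation channel subfamily M member 8 (Homo sapiens), read by fluorescence and calcium flux, with a stated time of 15 min (a lower number here means that less compound is needed, a higher number that more compound is needed for the effect), compound 1 gives 8 nM, whereas compound 3 gives 489 nM, a change of a 61-fold higher number from compound 1 to compound 3 (1.79 log units; beyond the scatter). Compound 2 `CCN(Cc1cncs1)C(=O)COc1ccc(C)cc1` gives 1100 nM in this assay, so compound 3 stands second highest of the three numbers, separated from compound 2 by a 2.2-fold lower number from compound 2 to compound 3 (0.35 log units; beyond the scatter) and from compound 1 by a far larger gap. The largest swing in the set is a 140-fold higher number from compound 1 to compound 2 (2.14 log units; beyond the scatter).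

Compound 4 `CCN(Cc1cccn1C)C(=O)COc1ccc(C)cc1` differs from compound 3 only in the ring on the saturated chain carbon bound to the amide-type nitrogen: 1-methyl-1H-pyrrol-2-yl in place of furan-2-yl on a saturated chain carbon bound to an amide-type nitrogen. Going by the values given here, no measured step involves a 1-methyl-1H-pyrrol-2-yl group, so the only guidance is that rings of this class at this position range widely in this assay, with a sulfur-containing ring at one extreme and the oxygen- and nitrogen-containing rings clustered at the other. The two rings that resemble compound 4 most closely, in compounds 2 and 3, lie within a modest step of each other, so a step of at most modest size is expected in either direction.

Compound 4 is therefore estimated at 300 nM, within 60 nM to 1500 nM, which is expected to correspond to a 1.6-fold lower number from compound 3 to compound 4 (0.21 log units; within the scatter).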

Compound 4, half-maximal effective concentration: 21300 nM
For compound 4 the middle estimate is 71-fold (1.85 log units) below the measured one; the measured number lies above the stated range.
By their numbers in this assay, from the lowest: compound 1; then compound 3; then compound 2; then compound 4.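

In this assay, the 1-methyl-1H-pyrrol-2-yl ring of compound 4 gives the highest number of the four compounds, and this position on a saturated chain carbon bound to an amide-type nitrogen therefore spans a wider range than the three earlier rings showed, with the steps reading (a 44-fold higher number from compound 3 to compound 4 (1.64 log units; beyond the scatter)) and (a 19-fold higher number from compound 2 to compound 4 (1.29 log units; beyond the scatter)) and (a 2700-fold higher number from compound 1 to compound 4 (3.43 log units; beyond the scatter)). The step from furan-2-yl to 1-methyl-1H-pyrrol-2-yl is large even though both are five-membered aromatic rings with 1 hetero atom, 0 hydrogen-bond donors and 1 hydrogen-bond acceptor, so these counts do not settle the number here, and the oxygen- and nitrogen-containing rings no longer form a single cluster. No available evidence bears on why this change has so large an effect.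

The compounds shown leave open whether the step follows from the ring nitrogen or from the methyl group on it, a question that a 1H-pyrrol-2-yl ring, carrying a hydrogen in place of that methyl, would address. They also leave open how a thiophen-3-yl ring would compare with the thiophen-2-yl ring of compound 1 at this position.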